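From Fluoro to Trifluoromethyl on the Shared Core

The source may report more compounds than this note shows. Statements on the series, on what has been measured and on what is new or still open speak of the compounds shown alone.

Of the compounds shown here, three share a core and have been measured in an assay (Populus sieboldii x Populus grandidentata) for inhibition of Trans-cinnamate 4-monooxygenase (Populus kitakamiensis), with a stated time of 60 min; on this read-out lower numbers stand for stronger inhibition and higher numbers for weaker inhibition. Compound 1 `Sc1nnc(-c2ccco2)o1` carries a furan ring on that core and gives 5900 nM. Compound 2 `Cc1cccc(-c2nnc(S)o2)c1` carries a methyl-bearing benzene ring instead and gives 1100 nM. Compound 3 `Fc1cccc(-c2nnc(S)o2)c1` carries a fluoro-bearing benzene ring and gives 130 nM, the lowest of the three numbers and therefore the strongest inhibition seen so far; compound 2 comes nearest and compound 1 lies furthest. The single one-place step among these is an 8.5-fold lower number from compound 2 to compound 3 (0.93 log units; beyond the scatter), which shows that a small change on an aromatic carbon can move the read-out well beyond the scatter.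

Compound 4 `FC(F)(F)c1cccc(-c2nnc(S)o2)c1` is not yet measured. It differs from compound 3 by trifluoromethyl in place of fluoro on an aromatic carbon. Among the compounds with values here, only the step from methyl to fluoro bears on this change, and it was modest in size but clear in direction. A trifluoromethyl group is neither of those two groups, so the direction is uncertain; the expectation in this assay is a small move toward a higher number. The estimate therefore amounts to a 1.9-fold higher number from compound 3 to compound 4 (0.28 log units; within the scatter). Compound 4 is expected to give about 250 nM, within a range from 50 nM to 1200 nM.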

Compound 4, half-maximal inhibitory concentration: > 100000 nM
Compound 4: no number, only a limit; the forecaster's own chance of this, stated with the estimate: 5%; at least 400-fold (2.60 log units) between middle value and limit.
By their numbers in this assay, from the lowest: compound 3; then compound 2; then compound 1. At a limit, above all of these: compound 4.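

In this assay compound 4 gives > 100000 nM and this is a limit of the assay and not a number: the limit of > 100000 nM in this assay, at which 1 of the 4 values shown sits.

Even so, the change can be read in one direction: trifluoromethyl in place of fluoro on this aromatic carbon gives an at least 760-fold higher number from compound 3 to compound 4 (2.88 log units; beyond the scatter) as its step, and trifluoromethyl in place of methyl gives an at least 90-fold higher number from compound 2 to compound 4 (1.95 log units; beyond the scatter) as its step. Within the data shown here, the earlier compounds showed only that swapping one small group for another on this carbon moves the read-out while inhibition stays measurable, whereas with trifluoromethyl on the same carbon no inhibition can be given a number at all.

The compounds shown cannot tell which feature of trifluoromethyl accounts for this sharp loss, or how far the true value lies past the limit. On these data alone, a chlorine atom, a methoxy group or an amine on the same aromatic carbon would show whether inhibition fades step by step or drops abruptly, and the effect of any of these groups on the other carbons of the six-membered ring also remains open.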